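A Ring Swap Starting From an Assay Limit

The source may hold more compounds than are shown below. What is called first, only, known or untested is meant among the compounds shown, and "the series" means these compounds.

In a functional assay on DU-145 cells (Homo sapiens) for inhibition (on this read-out higher numbers stand for weaker inhibition and lower numbers for stronger inhibition), compound 1 (`Oc1cccc(-c2cc(-c3cccc(F)c3)cc(-c3ccccc3O)n2)c1`) gives > 50000 nM and this is a limit of the assay, not a number. Compound 2 (`Oc1ccc(-c2cc(-c3cccc(F)c3)cc(-c3ccccc3O)n2)cc1`) gives > 50000 nM and this is also a limit. So compound 2 stands only at the limit of > 50000 nM in this assay, at which 2 of the 2 values shown sit, and has no exact potency to build on.

Compound 3 (`Oc1ccc(-c2cc(-c3ccc(C(F)(F)F)cc3)cc(-c3ccccc3O)n2)cc1`) differs from compound 2 by one group: 4-(trifluoromethyl)phenyl in place of 3-fluorophenyl on an aromatic carbon is the change. Its 4-(trifluoromethyl)phenyl takes the place of the 3-fluorophenyl, opposite the ring nitrogen.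

Going by the values given here, the only measured step is a step that the two limits leave unreadable from compound 1 to compound 2 and it offers no size to carry over. It also concerns the hydroxyphenyl group, not the group exchanged here. Nothing measured therefore fixes a direction, so the expectation is cautious: a modest move toward stronger inhibition in this assay or no readable change at all. The expected step is an at least 1.6-fold lower number from compound 2 to compound 3 (0.22 log units; that floor lies within the scatter) and it remains only an estimate. Compound 3 is estimated at 30000 nM with an expected range from 6000 nM to 60000 nM in this measurement.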

Compound 3, half-maximal inhibitory concentration: > 50000 nM
Compound 3 ended at the assay's limit (the forecaster's own chance of this, stated with the estimate: 50%); at least 1.6-fold (0.22 log units) between middle value and limit.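

In this assay compound 3 gives > 50000 nM, which is a limit of the assay and not a number. Compound 2 also stands at a limit, so the step between compound 2 and compound 3 cannot be read: the limit of > 50000 nM in this assay, at which 3 of the 3 values shown sit. The compounds shown leave open what exact potency any of them has and whether any group on the shared core gives a measurable value.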